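The source may report more compounds than this note shows. Statements on the series, on what has been measured and on what is new or still open speak of the compounds shown alone.

In a functional assay on SK-MEL-28 cells (Homo sapiens) for antiproliferative activity, read by MTT assay, with a stated time of 72 h (on this read-out higher numbers stand for weaker inhibition and lower numbers for stronger inhibition), three compounds have been measured. Compound 1, with the structure `O=C1Nc2c(Cl)cccc2/C1=C1/Nc2ccccc2C1=O`, reaches only the limit of the assay, giving > 100000 nM. Compound 2, with the structure `O=C1Nc2ccccc2/C1=C1/Cc2ccccc2C1=O`, likewise reaches only the limit, giving > 100000 nM. For the measured compounds named here, compound 3, with the structure `O=C1NC(=S)N/C1=C1\C(=O)Nc2ccccc21`, is the single compound that returns a number rather than a limit: in this assay compound 3 gives 62900 nM. It therefore stands alone among the values shown, the other two sitting at the limit of > 100000 nM in this assay, at which 2 of the 3 values shown sit.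

Compound 4, with the structure `O=C1NC(=S)N/C1=C1\C(=O)Nc2c(Br)cccc21`, is yet to be measured. It differs from compound 3 in one place: bromo in place of hydrogen on an aromatic carbon. The bromo enters on an aromatic carbon of a six-membered aromatic ring of carbon only, part of a fused system of two rings, ortho to a fused ring and meta to a fused ring. Going by the values given here, no measured pair in the set isolates this kind of change on this core, so the expectation rests on compound 3 alone. Compound 4 is expected to stay close to compound 3, with the step of a 1.3-fold lower number from compound 3 to compound 4 (0.10 log units; within the scatter) in this assay estimated as small and not beyond the scatter in either direction. Compound 4 is accordingly estimated at 50000 nM, within the range 15000 nM to 150000 nM.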

Compound 4, half-maximal inhibitory concentration: 11700 nM
Estimate against measurement, compound 4: 4.3-fold (0.63 log units) above; measured number below the stated range.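

In this assay, bromo in place of hydrogen on an aromatic carbon, ortho to a fused ring and meta to a fused ring, gives a 5.4-fold lower number from compound 3 to compound 4 (0.73 log units; beyond the scatter), so this position on the shared core responds to a single substitution by more than the scatter. For the compounds shown here, the earlier compounds could not show this, as they held one number and no pair differing in one place; this is the first readable step on this core, and it runs toward stronger inhibition. It comes from a change of one heavy atom, with no ring, no hydrogen-bond donor or acceptor and no net charge, and the other compounds add no second number, each sitting at a limit: the limit of > 100000 nM in this assay, at which 2 of the 4 values shown sit.

As far as these compounds go, whether the step belongs to bromo itself or would also follow from a methyl, a methoxy or an amine on the same carbon stays open, as does whether bromo on the other aromatic carbons of that ring would give a similar step. The compounds shown also do not tell why the number falls, as they hold no measured property of the bromo.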